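Swapping Bromo for Nitro on a Weakly Cytotoxic Pair

The source may hold more compounds than are shown below. What is called first, only, known or untested is meant among the compounds shown, and "the series" means these compounds.

Compound 1, `O=c1ccoc2cc(OCc3cn(Cc4cccc(Br)c4)nn3)ccc12`, in a functional assay on SW480 cells (Homo sapiens) for cytotoxicity, read by MTT assay, with a stated time of 48 h (on this read-out lower numbers stand for stronger inhibition and higher numbers for weaker inhibition), gives > 100000 nM.
Compound 2, `O=c1ccoc2cc(OCc3cn(Cc4ccc(Br)cc4)nn3)ccc12`, in this assay gives 37500 nM.

Compound 1 sits at a limit of this assay rather than at a number; the limit of > 100000 nM in this assay, at which 1 of the 2 values shown sits, marks where it stands. Among the compounds with values here, compound 2 holds the only actual number in this pair. Within the data shown here, the one measured step is an at least 2.6-fold lower number from compound 1 to compound 2 (0.42 log units; beyond the scatter), a move of bromine from one position on the phenyl ring to another.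

Compound 3, `O=c1ccoc2cc(OCc3cn(Cc4ccc([N+](=O)[O-])cc4)nn3)ccc12`, differs from compound 2 by nitro in place of bromo on an aromatic carbon. Among the measured compounds shown here, no measured step compares two different groups at the same place on this ring, so the single known step bears on the change only loosely: it shows that the ring substituent can shift the read-out, but not in which direction a nitro group would take it. The expected step of a 1.1-fold higher number from compound 2 to compound 3 (0.03 log units; within the scatter) from compound 2 to compound 3 is therefore small. Compound 3 is expected at 40000 nM, with a range from 10000 nM to 150000 nM.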

Compound 3, half-maximal inhibitory concentration: 19300 nM
For compound 3 the middle estimate is 2.1-fold (0.32 log units) above the measured one; the measured number falls inside the stated range.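

Bromo and nitro can now be compared directly at the same place on the ring, para to a large group, and the swap gives a 1.9-fold lower number from compound 2 to compound 3 (0.29 log units; within the scatter), so in this assay these two groups cannot be told apart. The 4-nitrophenyl group in place of the 3-bromophenyl group gives an at least 5.1-fold lower number from compound 1 to compound 3 (0.71 log units; beyond the scatter), which means that a second group at this place, not only bromo, stands clear of compound 1. Compound 1 itself marks a limit and not a number, so this step has no exact size: the limit of > 100000 nM in this assay, at which 1 of the 3 values shown sits.

From the compounds shown here alone, whether a different kind of group at this place, such as an amine or a carboxylic acid, would move the read-out beyond the scatter remains open. It is also unknown how nitro would behave at the place that the bromine occupies in compound 1.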